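The source may report more compounds than this note shows. Statements on the series, on what has been measured and on what is new or still open speak of the compounds shown alone.

Three compounds have been measured in a functional assay on a cell-free system (plasma, Homo sapiens), with a stated time of 3 min (on this read-out lower numbers stand for stronger inhibition and higher numbers for weaker inhibition), so far:

compound 1 `CC(C)(C)OC[C@@H](O)C(=O)N1[C@H](C(=O)NCc2cc(Cl)ccc2-n2cnnn2)C[C@@H]2C[C@@H]21` gives 500 nM
compound 2 `O=C(NCc1cc(Cl)ccc1-n1cnnn1)[C@@H]1[C@H]2C[C@H]2CN1C(=O)[C@H](O)C1CCCCC1` gives 850 nM
compound 3 `CCCC[C@@H](O)C(=O)N1[C@@H]2C[C@@H]2C[C@H]1C(=O)NCc1cc(Cl)ccc1-n1cnnn1` gives 870 nM

Compound 1, at 500 nM in this assay, lies within the usual scatter of both compound 2 (850 nM) and compound 3 (870 nM), so these numbers do not rank the three.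

Compound 4 `O=C(NCc1cc(Cl)ccc1-n1cnnn1)[C@@H]1C[C@@H]2C[C@@H]2N1C(=O)[C@H](O)Cc1ccccn1` has yet to be measured. It differs from compound 1 by pyridin-2-yl in place of tert-butoxy on a saturated chain carbon, two bonds along the chain from a carbonyl carbon and an oxygen on a saturated carbon and the same difference, cut one bond further out, reads (tert-butoxy)methyl to (pyridin-2-yl)methyl.

For the measured compounds named here, no measured pair differs in only one place, so the data show no direct precedent for this exchange. Going by the values given here, the only guide is the close grouping of the three values, and on that basis no step beyond the scatter is expected in this assay in either direction. The estimated change is a 1.4-fold higher number from compound 1 to compound 4 (0.15 log units; within the scatter) and this is small enough to leave compound 4 among the measured compounds. Compound 4 is expected at 700 nM within an estimated range of 250 nM to 2000 nM in this read-out.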

Compound 4, half-maximal inhibitory concentration: 1000 nM
Estimate against measurement, compound 4: 1.4-fold (0.15 log units) below; low and high end bracket the measured number.
By their numbers in this assay, from the lowest: compounds 1, 2, 3 and 4 (each within the scatter of the next).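

In this assay, for the compounds shown here, pyridin-2-yl in place of tert-butoxy on a saturated chain carbon, two bonds along the chain from a carbonyl carbon and an oxygen on a saturated carbon, gives a 2.0-fold higher number from compound 1 to compound 4 (0.30 log units; within the scatter), and this is the first step that can be read at a single place. It shows that a six-membered aromatic ring can stand where a ringless ether group stood without moving the number beyond the scatter, so this read-out does not separate the two groups at this position, even though the exchange adds a ring and replaces the oxygen of the leaving group with a ring nitrogen. No independent measurement bears on why the two compounds read alike.

The compounds shown leave open whether phenyl, pyridin-3-yl or pyridin-4-yl at this position would read any differently from pyridin-2-yl, and whether an amine or a carboxylic acid there would produce a step beyond the scatter. Going by these compounds alone, they also leave open whether the same exchange would behave alike on the core of compound 2, since no pair offers that comparison.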